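Replacing 3-nitrophenyl with 4-methylphenyl: working notes

A few compounds are considered here, and "the series" means these few. Any claim that something is new, unique, unknown or untested is made for them only; others in the source may bear on it.

In an ADME assay on HEK293 cells (Homo sapiens) for cytotoxicity, read by MTT assay, with a stated time of 48 h (a lower number here means a stronger inhibitor, a higher number a weaker inhibitor), compound 1 (`C#CC1=CC[C@@]2(C)C(=C)CCC[C@]2(C)CC1`) gives 524000 nM and compound 2 (`C=C1CCC[C@]2(C)CCC(c3cn(-c4cccc([N+](=O)[O-])c4)nn3)=CC[C@@]12C`) gives 699000 nM on the same read-out. Compound 2 therefore stands within the scatter of compound 1, and the two numbers cannot be told apart. Among the measured compounds shown here, no measured pair yet differs in one place only, so the series offers no direct reading of a single change.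

Compound 3 (`C=C1CCC[C@]2(C)CCC(c3cn(-c4ccc(C)cc4)nn3)=CC[C@@]12C`) is still unmeasured. It carries 4-methylphenyl in place of 3-nitrophenyl on an aromatic nitrogen of the five-membered aromatic ring with 3 nitrogen (4-methylphenyl in place of 3-nitrophenyl on an aromatic nitrogen) and otherwise matches compound 2. In this assay no step beyond the scatter is expected for this change, in either direction, since compound 2 at 699000 nM and compound 1 at 524000 nM show no measured spread to build on. The estimated step is a 1.2-fold lower number from compound 2 to compound 3 (0.08 log units; within the scatter) and remains an expectation only. For compound 3 the expected value is 580000 nM with an estimated range from 250000 nM to 1100000 nM on this read-out.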

Compound 3, half-maximal inhibitory concentration: 524000 nM
Beside the measured number, compound 3's estimate is 1.1-fold (0.04 log units) above it; low and high end bracket the measured number.
By their numbers in this assay, from the lowest: compounds 1, 3 and 2 (each within the scatter of the next).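

In this assay, among the compounds shown here, the first reading of a single change is a 1.3-fold lower number from compound 2 to compound 3 (0.13 log units; within the scatter), for 4-methylphenyl in place of 3-nitrophenyl on an aromatic nitrogen of the five-membered aromatic ring with 3 nitrogen. At this position, a group of 9 heavy atoms with 2 hydrogen-bond acceptors and a group of 7 heavy atoms with 0 hydrogen-bond acceptors cannot be told apart on this read-out, so this exchange gives no measurable handle on cytotoxicity in these cells. No measurement on hand bears on why the two substituted phenyl groups read alike.

The step swaps the substituent and changes its place on the phenyl ring in one move, so it cannot show whether either alone would leave the number within the scatter. It also leaves open whether a more different group on the same aromatic nitrogen, such as an aminophenyl, a carboxylic acid on the phenyl ring or a longer alkyl chain in place of the ring, would produce a step beyond the scatter.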